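Swapping Dimethylamino for Methyl on the Shared Core

This account rests on a few compounds, and the source may have more. Where it says the series, first, only, none or still open, it means among the compounds named here.

Compound 1 `CNc1nc(-c2cc(OC)c(OC)c(OC)c2)c(-c2ccc(C)cc2)s1`: 18.1 nM
Compound 2 `COc1cc(-c2nc(N(C)C)sc2-c2ccc(C)cc2)cc(OC)c1OC`: 3480 nM

Both numbers come from a functional assay on HL-60 cells (Homo sapiens) for antiproliferative activity, read by MTT assay, with a stated time of 72 h (on this read-out lower numbers stand for stronger inhibition and higher numbers for weaker inhibition), where compound 2 stands as the higher of the two at 3480 nM. For the measured compounds named here, the only measured step, a 190-fold higher number from compound 1 to compound 2 (2.28 log units; beyond the scatter), is large. Compound 3 `COc1cc(-c2nc(C)sc2-c2ccc(C)cc2)cc(OC)c1OC` changes the same place on the shared core, with methyl in place of dimethylamino on an aromatic carbon. The measured step bears on this only in part: it added a methyl on a nitrogen, whereas here the nitrogen itself goes. Going by the values given here, no measured compound carries methyl at this place, so the uncertainty is wide. A partial move toward compound 1, at 18.1 nM, is expected in this assay. The expected size is a 4.4-fold lower number from compound 2 to compound 3 (0.64 log units; beyond the scatter). The estimate for compound 3 is 800 nM, with an expected range of 100 nM to 5000 nM.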

Compound 3, half-maximal inhibitory concentration: 1510 nM
Compound 3: the middle estimate sits 1.9-fold (0.28 log units) below what was measured; low and high end bracket the measured number.
By their numbers in this assay, from the lowest: compound 1; then compound 3; then compound 2.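

In this assay, taking the nitrogen away from this position recovers very little: a 2.3-fold lower number from compound 2 to compound 3 (0.36 log units; beyond the scatter) is a modest gain, while an 83-fold higher number from compound 1 to compound 3 (1.92 log units; beyond the scatter) leaves methyl far short of methylamino. Methyl has fewer heavy atoms than dimethylamino, yet among these three groups only methylamino gives a low number, so a smaller group at this place does not by itself restore the value of compound 1. No evidence is available to explain the differences among these three groups.

The compounds shown leave open whether a plain amine or an ethylamino group at this place would match or improve on methylamino. They also leave open whether a hydroxyl group here would behave more like methylamino or like methyl.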